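The compounds below may be only part of what the source reports. "The series", "measured", "known", "first", "only" and "open" are said of these compounds alone.

Working notes on the series.

Compound 2, `COc1ccc(Cc2nn3cc(-c4cccc(N)c4)nc3s2)cc1`, gives 100000 nM in a functional assay on FM3A cells (Mus musculus) for inhibition, read by cell counting, with a stated time of 2 days; on this read-out lower numbers stand for stronger inhibition and higher numbers for weaker inhibition. Compound 1, `Nc1cccc(-c2cn3nc(Cc4ccccc4)sc3n2)c1`, gives 4700 nM in this assay, and the step of a 21-fold lower number from compound 2 to compound 1 (1.33 log units; beyond the scatter) goes with the change (hydrogen in place of methoxy on an aromatic carbon).

Compound 3, `COc1cccc(-c2nn3cc(-c4cccc(N)c4)nc3s2)c1`, gives 29000 nM in this assay. The difference between the core of compound 3 and the core of compound 2 is not broken down here. Compound 4, `Nc1cccc(-c2cn3nc(-c4ccccc4)sc3n2)c1`, has not yet been measured in this assay; it differs from compound 3 by hydrogen in place of methoxy on an aromatic carbon. This is the same kind of change as from compound 2 to compound 1, but the place differs: the group leaving compound 2 sits para to a large group, the group leaving compound 3 sits meta to a large group.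

Given the earlier step of a 21-fold lower number from compound 2 to compound 1 (1.33 log units; beyond the scatter), the step is expected to be a 7.3-fold lower number from compound 3 to compound 4 (0.86 log units; beyond the scatter), on a different core and at a different place, so with less confidence. Compound 4 is expected to give about 4000 nM in this assay, between 1000 nM and 20000 nM.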

Compound 4, half-maximal inhibitory concentration: 14000 nM
Beside the measured number, compound 4's estimate is 3.5-fold (0.54 log units) below it; the range from low to high includes it.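

In this assay, hydrogen in place of methoxy gives a 2.1-fold lower number from compound 3 to compound 4 (0.32 log units; beyond the scatter), the same direction as the earlier step, but the size does not carry from one core to the other: the same change on two cores in this assay, a 21-fold lower number (1.33 log units; beyond the scatter) from compound 2 to compound 1 and a 2.1-fold lower number (0.32 log units; beyond the scatter) from compound 3 to compound 4, 10-fold (1.01 log units) apart, beyond the scatter of two such steps. Among these compounds, with only two pairs, and with the methoxy at a different place in each, these data do not separate the role of the core from that of the place. Among the compounds without methoxy, phenyl in place of benzyl goes with a 3.0-fold higher number from compound 1 to compound 4 (0.47 log units; beyond the scatter).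

Going by these compounds, it remains open how either core responds to other groups at these places, such as a carboxylic acid or a fluorine. Also open, on these data alone, is whether a longer chain in place of benzyl would extend the step from phenyl to benzyl.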